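The source may report more compounds than this note shows. Statements on the series, on what has been measured and on what is new or still open speak of the compounds shown alone.

Measured in an assay for inhibition of inositol hexakisphosphate kinase 2 (Homo sapiens), read by colorimetric assay, coupled enzyme assay and malachite green, with a stated time of 120 min, in the presence of a further agent that is not named here; on this read-out higher numbers stand for weaker inhibition and lower numbers for stronger inhibition:
compound 1 `Cc1cccc(-c2onc3ccc(/C=C/C(=O)O)cc23)c1`, 290 nM
compound 2 `Cc1cccc(-c2onc3ccc(C(=O)O)cc23)c1`, 150 nM
compound 3 `O=C(O)c1ccc2noc(-c3cccc(Oc4ncc(Cl)cc4Cl)c3)c2c1`, 71 nM

Compound 2 holds the second highest of the three numbers. Its nearest neighbour is compound 1, with a 1.9-fold lower number from compound 1 to compound 2 (0.29 log units; within the scatter); furthest is compound 3, with a 2.1-fold lower number from compound 2 to compound 3 (0.32 log units; beyond the scatter). Compound 4 `Cc1cc(C)cc(-c2onc3ccc(C(=O)O)cc23)c1` differs from compound 2 by methyl in place of hydrogen on an aromatic carbon. Among the measured compounds shown here, no measured step repeats this change. The step from compound 2 to compound 3 touches the same ring, but exchanges the methyl rather than adding a second one, and was only modest. The step from compound 1 to compound 2 concerns the acid side and does not bear on it. A second methyl at this place is therefore expected to move this assay little, if at all, with no step beyond the scatter. Compound 4 is estimated at 130 nM, in the range 50 nM to 400 nM, the expected step being a 1.2-fold lower number from compound 2 to compound 4 (0.06 log units; within the scatter).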

Compound 4, half-maximal inhibitory concentration: 100 nM
The estimate for compound 4 lay 1.3-fold (0.11 log units) above the measured number, within the range that was stated.
By their numbers in this assay, from the lowest: compounds 3, 4, 2 and 1 (each within the scatter of the next, the first and the last beyond it).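

Placed on an aromatic carbon meta to a large group and meta to a methyl group, the added methyl gives a 1.5-fold lower number from compound 2 to compound 4 (0.18 log units; within the scatter) in this assay, so this position accepts a methyl alongside the existing one without a change beyond the scatter. The earlier compounds shown here showed only the exchange of that existing methyl, not an addition to the ring that keeps it. Nothing measured here accounts for this result.

Going by these compounds, whether a longer chain such as ethyl, a methoxy group or an amine would be accepted at this position remains open. On these data alone, it is also open whether this added methyl would leave the number unchanged beside the (3,5-dichloropyridin-2-yl)oxy group of compound 3.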